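A few compounds are considered here, and "the series" means these few. Any claim that something is new, unique, unknown or untested is made for them only; others in the source may bear on it.

Among the compounds with values here, in a functional assay on IMR-32 cells (Homo sapiens) for antiproliferative activity, read by sulforhodamine B assay, with a stated time of 48 h (on this read-out lower numbers stand for stronger inhibition and higher numbers for weaker inhibition), compound 1 `COc1ccc(C[C@@H](O)/C=C/C=C/C(=O)N2CCN(C)CC2)cc1OC` gives 18900 nM and compound 2 `COc1ccc(C[C@@H](O)/C=C/C=C/C(=O)N2CCCC2)cc1OC` gives 12000 nM, so compound 2 stands within the scatter of the only other measured compound. Compound 3 `COc1ccc(C[C@@H](O)/C=C/C=C/C(=O)NCc2ccccc2)cc1OC` differs from compound 2 by benzylamino in place of pyrrolidin-1-yl on a carbonyl carbon, with benzylamino in place of pyrrolidin-1-yl on a carbonyl carbon. Within the data shown here, only one measured step bears on this place: a 1.6-fold lower number from compound 1 to compound 2 (0.20 log units; within the scatter), which is within the scatter. Among the measured compounds shown here, no benzylamino compound has been measured, so the expectation is loose, and no step beyond the scatter is expected: a 1.2-fold lower number from compound 2 to compound 3 (0.08 log units; within the scatter). For compound 3 the estimated value is 10000 nM, with an expected range from 3500 nM to 30000 nM.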

Compound 3, half-maximal inhibitory concentration: 16600 nM
Beside the measured number, compound 3's estimate is 1.7-fold (0.22 log units) below it; the measured number falls inside the stated range.
By their numbers in this assay, from the lowest: compounds 2, 3 and 1 (each within the scatter of the next).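

In this assay, the change to benzylamino on this carbonyl carbon gives a 1.4-fold higher number from compound 2 to compound 3 (0.14 log units; within the scatter) and a 1.1-fold lower number from compound 1 to compound 3 (0.06 log units; within the scatter). At this position, then, a group with one hydrogen-bond donor and a six-membered aromatic ring of carbon only stands level with pyrrolidin-1-yl and 4-methylpiperazin-1-yl, which carry no donor and no aromatic ring. No measurement shown here offers an explanation for this result. As far as these compounds go, it remains open whether a group of another kind on this carbonyl carbon, such as a carboxylic acid or a phenethylamino group, would give a step beyond the scatter. The compounds also leave open how changes elsewhere on the shared core would read.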